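Ring contraction on the amine substituent of a kinase inhibitor series

The compounds below may be only part of what the source reports. "The series", "measured", "known", "first", "only" and "open" are said of these compounds alone.

Measured compounds:
- Compound 1, `N#Cc1cnc(NCc2cnccc2C(F)(F)F)cc1NC[C@H]1CC[C@H](O)CC1`, 2000 nM
- Compound 2, `CC1(C)C[C@H](Nc2cc(NCc3cnccc3C(F)(F)F)ncc2C#N)CC(C)(C)[C@@H]1O`, 700 nM
- Compound 3, `CC1(C)C[C@H](Nc2nc(NCc3cnccc3C(F)(F)F)ncc2C#N)CC[C@@H]1O`, 800 nM

In an assay on isolated protein for inhibition of protein kinase C delta type (Homo sapiens), read by TR-FRET, with a stated time of 2 h (on this read-out higher numbers stand for weaker inhibition and lower numbers for stronger inhibition), compound 3 gives 800 nM, the second highest of the three numbers. Its nearest neighbour is compound 2, whose value is within the scatter of it, so the two cannot be ordered; the furthest is compound 1, whose value lies beyond the scatter above that of compound 3.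

Compound 4, `CC1(C)[C@H](O)C[C@@H]1Nc1nc(NCc2cnccc2C(F)(F)F)ncc1C#N`, has not yet been measured. It differs from compound 3 in one place: 3-hydroxy-2,2-dimethylcyclobutyl in place of 4-hydroxy-3,3-dimethylcyclohexyl on a nitrogen on an aromatic ring. Among the compounds with values here, since no measured pair in this set carries that change, nothing here says how the ring contraction will read. The shared core of compound 3 and compound 4 is untouched, so a moderate step is expected, more likely upward than downward, as a 1.9-fold higher number from compound 3 to compound 4 (0.27 log units; within the scatter). The value of compound 4 in this assay is therefore estimated at 1500 nM, with a range from 500 nM to 5000 nM.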

Compound 4, half-maximal inhibitory concentration: 8500 nM
Compound 4: the middle estimate sits 5.7-fold (0.75 log units) below what was measured; measured number outside the range, above it.
By their numbers in this assay, from the lowest: compounds 2 and 3 (each within the scatter of the next); then compound 1; then compound 4.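

In this assay, within the data shown here, the single change of 3-hydroxy-2,2-dimethylcyclobutyl in place of 4-hydroxy-3,3-dimethylcyclohexyl gives an 11-fold higher number from compound 3 to compound 4 (1.03 log units; beyond the scatter) on an otherwise unchanged shared core. Among these compounds, this is the first step in the set that isolates one place, and it shows that the group on this nitrogen can by itself move the number well beyond the scatter, although both groups hold 1 hydrogen-bond donor and 1 hydrogen-bond acceptor. No measurement offered here accounts for the size of this step.

The compounds shown leave open whether ring size or the placing of the hydroxy and dimethyl groups decides the outcome, as the two rings differ in all of these at once. They also leave open how a hydroxy-dimethylcyclopentyl group, with its five-membered ring of carbon, would read, and whether an amine in place of the hydroxy would change the picture.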